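Replacing trifluoromethyl with cyano in a more stable compound

This account rests on a few compounds, and the source may have more. Where it says the series, first, only, none or still open, it means among the compounds named here.

- compound 1 `Cc1cc(F)cnc1N1CCN(C(=O)CCCc2cccc3ncoc23)[C@@H](C)C1`: 0%
- compound 2 `O=C(CCS(=O)(=O)c1cccc2ncsc12)N1CCN(c2ccc(C(F)(F)F)cn2)CC1`: 41%

For the measured compounds named here, in an ADME assay on microsomes from liver (Rattus norvegicus) for metabolic stability, read by LC-MS, with a stated time of 15 min, tested at 1 uM (on this read-out higher numbers stand for a more stable compound and lower numbers for a less stable compound), compound 2 stands highest of the two numbers so far at 41%. Its nearest neighbour, compound 1, gives 0%, a gap beyond the usual scatter. The next compound to be tested is compound 3 `N#Cc1ccc(N2CCN(C(=O)CCS(=O)(=O)c3cccc4ncsc34)CC2)nc1`, which differs from compound 2 in one place: cyano in place of trifluoromethyl on an aromatic carbon. Going by the values given here, no measured step yet shows what this change does, so any forecast is uncertain, and a fall cannot be ruled out. The expected change is a modest rise, estimated as a number 14 percentage points higher from compound 2 to compound 3 (beyond the scatter). In this assay, the estimate for compound 3 is 55%, with an expected range from 30% to 80%.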

Compound 3, percent of the compound remaining: 59%
Estimate against measurement, compound 3: 4 percentage points below, and the stated range covers the measured number.
By their numbers in this assay, from the lowest: compound 1; then compound 2; then compound 3.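

In this assay, for the compounds shown here, putting cyano in place of trifluoromethyl on this aromatic carbon, two atoms from the ring nitrogen and para to a large group, gives a number 18 percentage points higher from compound 2 to compound 3 (beyond the scatter), the first step here that can be read as a single change. Everything else in the molecule stays the same, so this position clearly matters for the read-out, and the group with 2 heavy atoms outperforms the one with 4 at this site. Nothing available explains why the number rises.

As far as these compounds go, this is one pair of compounds, so it remains unknown whether a methoxy group, a chlorine atom or an amine at the same carbon would give a higher or lower number. From the compounds shown here alone, whether the same swap would give a similar step on a different core, such as that of compound 1, also remains open.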